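One Sulfonyl Swap Within a Set of Inactive Compounds

A few compounds are considered here, and "the series" means these few. Any claim that something is new, unique, unknown or untested is made for them only; others in the source may bear on it.

Compounds 1, 2 and 3, which share one core, have been tested in an ADME assay on HCT-116 cells (Homo sapiens) for cytotoxicity, read by CellTiter-Glo, with a stated time of 72 h (on this read-out lower numbers stand for stronger inhibition and higher numbers for weaker inhibition), so far, and none of them has produced a measurable number. Compound 1 `CC1CCN(C2CCN(S(=O)(=O)c3cn(C)c(=O)n(C)c3=O)CC2)CC1` gives > 10000 nM, which is a limit of the assay rather than a measured value. Compound 3 `CC1CCN(C2CCN(S(=O)(=O)c3ccc(-c4ccc(Cl)cc4)cc3)CC2)CC1` gives > 5000 nM, also a limit. Compound 2 `Cc1noc(C)c1S(=O)(=O)N1CCC(N2CCC(C)CC2)CC1` gives > 10000 nM, again a limit and not a number, so compound 2 stands at the edge of what this assay can report, and the two further values shown are limits as well. Taken together, every result so far sits at one of two edges, because the limit of > 10000 nM in this assay, at which 2 of the 3 values shown sit, and the limit of > 5000 nM in this assay, at which 1 of the 3 values shown sits, account for all three values.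

Compound 4 `CC1CCN(C2CCN(S(=O)(=O)c3ccc(Br)c(Cl)c3)CC2)CC1` differs from compound 2 in one place: 4-bromo-3-chlorophenyl in place of 3,5-dimethyl-1,2-oxazol-4-yl on a sulfonyl sulfur. Among the measured compounds shown here, no step between two measured numbers exists in this set, so nothing shows whether such a change on the sulfonyl sulfur moves the read-out at all. Compound 3 carries a different halogenated phenyl group on the same sulfonyl sulfur and still reaches only > 5000 nM. The step from compound 2 to compound 4 is therefore expected to be a step that the limit leaves unreadable from compound 2 to compound 4, nothing beyond the scatter. For compound 4 the estimated result is 20000 nM, within a range from 5000 nM to 100000 nM, and most likely the assay will once more return only a limit.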

Compound 4, half-maximal inhibitory concentration: > 5000 nM
Compound 4: a limit, no number; the forecaster's own chance of this, stated with the estimate: 85%; the middle value does not contradict the limit.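

Compound 2 and compound 4 both return only a limit in this assay, not a measured number, so no step can be read between them. The compounds shown leave open whether 4-bromo-3-chlorophenyl in place of 3,5-dimethyl-1,2-oxazol-4-yl on a sulfonyl sulfur, or any other group there, changes the read-out at all.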